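The source may hold more compounds than are shown below. What is called first, only, known or untested is meant among the compounds shown, and "the series" means these compounds.

Working notes on the series.

Three compounds have been run in an assay on isolated protein for inhibition of Indoleamine 2,3-dioxygenase 1 (Homo sapiens), read by spectrophotometry; a lower number here means a stronger inhibitor, a higher number a weaker inhibitor. Compound 1 `O/N=C(/Nc1ccc(F)c(F)c1)c1ccc2occc2c1` gives 22700 nM in this assay. Compound 2 `O/N=C(/Nc1ccc(F)c(Cl)c1)c1ccc2occc2c1` differs from compound 1 by chloro in place of fluoro on an aromatic carbon, and in this assay compound 2 gives 5200 nM, so that the change produced a 4.4-fold lower number from compound 1 to compound 2 (0.64 log units; beyond the scatter). Compound 3 `OCc1cc2cc(/C(=N\O)Nc3cccc(F)c3)ccc2o1` is built on a different core; how the core of compound 3 differs from the core of compound 1 is not broken down here. In this assay compound 3 gives 1700 nM, the lowest of the three numbers, with both steps to the others beyond the scatter.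

Compound 4 `OCc1cc2cc(/C(=N\O)Nc3cccc(Cl)c3)ccc2o1` has not yet been measured. It differs from compound 3 by chloro in place of fluoro on an aromatic carbon. This is the same kind of change as that between compound 1 and compound 2, not the same change: in the earlier pair the place was also ortho to a fluoro group, while in compound 4 it is not, and in both pairs the place is meta to a large group.

Among the compounds with values here, compound 4 is expected to show a 2.8-fold lower number from compound 3 to compound 4 (0.45 log units; beyond the scatter) in this assay because the one earlier instance of this change gave a 4.4-fold lower number from compound 1 to compound 2 (0.64 log units; beyond the scatter), a step allowed to come out somewhat smaller since the surroundings of the place differ and a single example is thin support. Compound 4 is therefore estimated at 600 nM in this assay, within an expected range from 250 nM to 1500 nM.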

Compound 4, half-maximal inhibitory concentration: 8000 nM
The estimate for compound 4 lay 13-fold (1.12 log units) below the measured number, and the stated range ends below it.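

In this assay, chloro in place of fluoro on an aromatic carbon gives a 4.7-fold higher number from compound 3 to compound 4 (0.67 log units; beyond the scatter), so the change does not carry over from the core of compound 1 to the core of compound 3 with its direction intact, and the two steps are of similar size but opposite sign: the same change on two cores in this assay, a 4.4-fold lower number (0.64 log units; beyond the scatter) from compound 1 to compound 2 and a 4.7-fold higher number (0.67 log units; beyond the scatter) from compound 3 to compound 4, 21-fold (1.31 log units) apart, beyond the scatter of two such steps

In this series, then, the step seen on one pair is no guide to the direction of the same change on another, and compound 4 is the instance that goes against any general gain from chloro. What this does not show is which difference between the pairs is responsible, since compound 1 and compound 2 differ from compound 3 and compound 4 both in the core and in the further fluoro on the aromatic ring, and two pairs cannot separate these.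

The compounds shown leave open whether the reversal follows the core or the further fluoro, which a single aromatic ring pattern compared on both cores would settle. Also open, as far as these compounds go, is how a plain phenyl, or a methyl, methoxy or nitrile at the same place, would stand beside the fluoro and chloro compounds on either core.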